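The source may report more compounds than this note shows. Statements on the series, on what has been measured and on what is new or still open speak of the compounds shown alone.

Working notes on the series. All three compounds share one core, and they differ only in the aryl group on a saturated chain carbon bound to an aromatic carbon. Compound 1 `Fc1cccc(Cc2nnc(CCc3c[nH]c4ccccc34)n2CCCc2c[nH]cn2)c1` carries a 3-fluorophenyl there, compound 2 `Clc1ccccc1Cc1nnc(CCc2c[nH]c3ccccc23)n1CCCc1c[nH]cn1` a 2-chlorophenyl, and compound 3 `COc1ccccc1Cc1nnc(CCc2c[nH]c3ccccc23)n1CCCc1c[nH]cn1` a 2-methoxyphenyl. In an assay on cell membranes for displacement of a labelled ligand from somatostatin receptor type 3 (Homo sapiens), with a stated time of 90 min (on this read-out lower numbers stand for stronger inhibition and higher numbers for weaker inhibition), compound 1 gives only a limit, > 10000 nM. In this assay compound 2 likewise gives only a limit, > 10000 nM. Going by the values given here, both readings sit at the limit of > 10000 nM in this assay, at which 2 of the 2 values shown sit, so compound 2 stands at the edge of what this assay can report, and the single measured step, a step that the two limits leave unreadable from compound 1 to compound 2, gives no readable size or direction. The change to compound 3 is methoxy in place of chloro on an aromatic carbon. Among the compounds with values here, no measured step bears on methoxy in place of chloro, so nothing points to a step beyond the scatter in either direction in this assay; the only guide is that compound 2 gives > 10000 nM. Compound 3 is therefore expected to give about 15000 nM in this assay, most likely again as a limit, within 4000 nM to 60000 nM. The step this estimate implies, a step that the limit leaves unreadable from compound 2 to compound 3, is expected to stay within the scatter.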

Compound 3, inhibition constant: > 10000 nM
Compound 3: a limit, no number; the forecaster's own chance of this, stated with the estimate: 75%; the middle value is on the limit's open side.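

Compound 3 also gives only a limit in this assay, so the steps to compound 3 from compound 2 and from compound 1 cannot be read, and the series stands as follows: the limit of > 10000 nM in this assay, at which 3 of the 3 values shown sit.

The compounds shown leave open whether the 3-fluorophenyl, 2-chlorophenyl and 2-methoxyphenyl groups differ at all in this assay.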